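Swapping Fluorines for Chlorines on a Carbamate

A few compounds are considered here, and "the series" means these few. Any claim that something is new, unique, unknown or untested is made for them only; others in the source may bear on it.

Measured so far:
compound 1, `CC(C)=CCC1Cc2c(OC(=O)Nc3ccc(F)cc3F)cc(=O)n(CCCO)c2CC1(C)C`, 0%
compound 2, `CC(C)=CCC1Cc2c(OC(=O)Nc3ccc(F)c(F)c3)cc(=O)n(CCCO)c2CC1(C)C`, 0%

Both compounds were tested in a functional assay on PANC-1 cells (Homo sapiens) for inhibition, read by MTT assay, with a stated time of 24 h, tested at 10 uM; on this read-out higher numbers stand for more inhibition at the one concentration tested (going by the name of the read-out) and lower numbers for less inhibition. Compound 1 gives 0%, and compound 2 gives 0%, so compound 2 stands level with compound 1 at the digits recorded. Among the compounds with values here, the one step between them, no change at the digits printed from compound 1 to compound 2 (within the scatter), moves the 3,4-difluorophenyl group into the place of the 2,4-difluorophenyl group on the amide-type nitrogen and leaves the read-out unchanged within the scatter.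

Compound 3, `CC(C)=CCC1Cc2c(OC(=O)Nc3ccc(Cl)c(Cl)c3)cc(=O)n(CCCO)c2CC1(C)C`, has not yet been measured in this assay. It differs from compound 2 by 3,4-dichlorophenyl in place of 3,4-difluorophenyl on an amide-type nitrogen. Within the data shown here, the only measured step, no change at the digits printed from compound 1 to compound 2 (within the scatter), concerns a different kind of change on the same nitrogen and shows no movement at all, so there is no measured step that directly tells how the halogen exchange should behave. With both measured compounds at the floor of the read-out, the step is expected to be a number 5 percentage points higher from compound 2 to compound 3 (within the scatter), that is, nothing beyond the scatter. Compound 3 is therefore estimated to give 5%, with a range from 0% to 25%.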

Compound 3, a percentage reported as inhibition, at one concentration (the size of the read-out at that concentration, not a potency): 1.8%
Beside the measured number, compound 3's estimate is 3.2 percentage points above it; the range from low to high includes it.
By their numbers in this assay, from the lowest: compounds 1, 2 and 3 (each within the scatter of the next).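

Placing 3,4-dichlorophenyl on the amide-type nitrogen in place of 3,4-difluorophenyl gives, in this assay, a number 1.8 percentage points higher from compound 2 to compound 3 (within the scatter), so the earlier finding that moving a fluorine made no difference now extends to a change of the halogen itself. Set against the 2,4-difluorophenyl group, the same 3,4-dichlorophenyl group gives a number 1.8 percentage points higher from compound 1 to compound 3 (within the scatter), and so neither the kind of halogen nor the placing of the fluorines separates these compounds at the one concentration tested, although three compounds are too few to speak for halogens in general at this position. Nothing at hand bears on why the read-out stays so flat here.

What the compounds shown leave open is whether a group of another kind on the phenyl ring, such as an amine or a carboxylic acid, or a benzyl group in place of the phenyl on this nitrogen, would give a number beyond the scatter. They also leave open whether a change elsewhere on the shared core, such as a longer chain on the ring nitrogen, would matter more than any change at this position.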